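The source may hold more compounds than are shown below. What is called first, only, known or untested is meant among the compounds shown, and "the series" means these compounds.

Of the compounds shown here, three have been measured in an assay on VSM-A10 cells for antagonist activity at Endothelin-1 receptor (Rattus norvegicus); on this read-out lower numbers stand for stronger inhibition and higher numbers for weaker inhibition. Compound 3 `Cc1noc(NS(=O)(=O)c2cccc3c(NC(C)C)cccc23)c1C` gives the lowest number, 20 nM. Compound 1 `Cc1noc(NS(=O)(=O)c2cccc3c(CN(C)C)cccc23)c1C` gives 2800 nM, and compound 2 `Cc1noc(NS(=O)(=O)c2cccc3ccccc23)c1C` gives 20000 nM. The steps between them are all beyond the scatter: a 1000-fold lower number from compound 2 to compound 3 (3.00 log units; beyond the scatter), a 140-fold lower number from compound 1 to compound 3 (2.15 log units; beyond the scatter), and a 7.1-fold higher number from compound 1 to compound 2 (0.85 log units; beyond the scatter). All three steps concern the group on the aromatic carbon, and the isopropylamino group there gives by far the lowest number.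

Compound 4 `CCOC(=O)C(C)Nc1cccc2c(S(=O)(=O)Nc3onc(C)c3C)cccc12` keeps that amino group on the aromatic carbon and changes only its chain: ethoxycarbonyl in place of methyl on a saturated chain carbon bound to a nitrogen on an aromatic ring and a saturated chain carbon. Within the data shown here, no measured step touches this position, so the three steps above say how much the aromatic substituent matters but give no direct guide to what a larger chain on the nitrogen does. With the amino link retained, the expectation for compound 4 is a small step, a 2.0-fold higher number from compound 3 to compound 4 (0.30 log units; within the scatter), whose direction cannot be told from these data. The estimate for compound 4 in this assay is 40 nM, with a range from 8 nM to 250 nM.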

Compound 4, half-maximal inhibitory concentration: 400 nM
Compound 4: middle estimate off by 10-fold (1.00 log units), on the low side; the whole stated range lies below it.
By their numbers in this assay, from the lowest: compound 3; then compound 4; then compound 1; then compound 2.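

Replacing methyl with ethoxycarbonyl on this saturated chain carbon is not a neutral change: in this assay it gives (a 20-fold higher number from compound 3 to compound 4 (1.30 log units; beyond the scatter)), so the chain on the nitrogen matters as well as the group on the aromatic carbon. The (1-(ethoxycarbonyl)ethyl)amino group still gives a clear gain over hydrogen (a 50-fold lower number from compound 2 to compound 4 (1.70 log units; beyond the scatter)) and over (dimethylamino)methyl (a 7.0-fold lower number from compound 1 to compound 4 (0.85 log units; beyond the scatter)), so the larger chain gives up part of the benefit seen with isopropylamino, but not all of it. No measurement here explains the rise in the number.

The compounds shown leave open whether the rise belongs to the whole ethoxycarbonyl group or only to its ethyl part. A carboxylic acid, a primary amide or a plain longer carbon chain at this place could help separate those possibilities.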